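A few compounds are considered here, and "the series" means these few. Any claim that something is new, unique, unknown or untested is made for them only; others in the source may bear on it.

Compound 1 `CCN(CC)c1ccc2cc(C(=O)c3ccc(N4CCN(C(=O)CN5CCNCC5)CC4)cc3)oc2c1` carries a hydrogen on an amine nitrogen in a ring; in a functional assay on MCF7 cells (Homo sapiens) for cytotoxicity, read by MTT assay, with a stated time of 48 h (on this read-out higher numbers stand for weaker inhibition and lower numbers for stronger inhibition), compound 1 gives 5340 nM. Compound 2 `CCN(CC)c1ccc2cc(C(=O)c3ccc(N4CCN(C(=O)CN5CCN(S(=O)(=O)C6CC6)CC5)CC4)cc3)oc2c1` bears a cyclopropylsulfonyl on that nitrogen. In this assay compound 2 reaches only a limit of the assay, > 40000 nM. Compound 3 `CCN(CC)c1ccc2cc(C(=O)c3ccc(N4CCN(C(=O)CN5CCN(Cc6ccc(C#N)cc6)CC5)CC4)cc3)oc2c1` bears a 4-cyanobenzyl there. In this assay compound 3 likewise reaches only a limit, > 40000 nM. The picture is dominated by the limit of > 40000 nM in this assay, at which 2 of the 3 values shown sit. Both an at least 7.4-fold higher number from compound 1 to compound 2 (0.87 log units; beyond the scatter) and an at least 7.4-fold higher number from compound 1 to compound 3 (0.87 log units; beyond the scatter) weakened inhibition past that limit, while a step that the two limits leave unreadable from compound 2 to compound 3. Compound 4 `CCOC(=O)CN1CCN(CC(=O)N2CCN(c3ccc(C(=O)c4cc5ccc(N(CC)CC)cc5o4)cc3)CC2)CC1` differs from compound 2 by (ethoxycarbonyl)methyl in place of cyclopropylsulfonyl on an amine nitrogen in a ring. Since every measured replacement of that hydrogen pushed the number beyond the limit, compound 4 is expected to stay near it, a step of an at least 1.3-fold lower number from compound 2 to compound 4 (0.12 log units; that floor lies within the scatter). Compound 4 is estimated at 30000 nM, between 8000 nM and 60000 nM.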

Compound 4, half-maximal inhibitory concentration: > 40000 nM
Compound 4 gave a limit, no number (the forecaster's own chance of this, stated with the estimate: 50%); at least 1.3-fold (0.12 log units) between middle value and limit.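

Replacing the hydrogen on this ring nitrogen with (ethoxycarbonyl)methyl, a group with no ring, gives an at least 7.4-fold higher number from compound 1 to compound 4 (0.87 log units; beyond the scatter) in this assay, so a ring in the new group is not needed for this loss. Compound 4 gives only a limit, not a number, so its steps to compound 2 and compound 3 cannot be read. All three replacements now end at the same ceiling: the limit of > 40000 nM in this assay, at which 3 of the 4 values shown sit.

Going by these compounds, it remains open how far past that limit these compounds lie. On these data alone, it is also open whether a methyl, or a 2-aminoethyl chain, on this nitrogen would keep the inhibition of compound 1.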